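Working notes: from compound 3 to compound 4

A few compounds are considered here, and "the series" means these few. Any claim that something is new, unique, unknown or untested is made for them only; others in the source may bear on it.

- compound 1 `OC[C@H]1O[C@@H](n2cnc3c(NCc4ccc(Cl)cc4)ncnc32)[C@H](O)[C@@H]1O`: > 166000 nM (a limit)
- compound 2 `COc1cccc(CNc2ncnc3c2ncn3[C@@H]2O[C@H](CO)[C@@H](O)[C@H]2O)c1`: > 166000 nM (a limit)
- compound 3 `OC[C@H]1O[C@@H](n2cnc3c(NCc4ccc(F)cc4F)ncnc32)[C@H](O)[C@@H]1O`: > 166000 nM (a limit)
- compound 4 `OC[C@H]1O[C@@H](n2cnc3c(NCc4ccc(F)c(Cl)c4)ncnc32)[C@H](O)[C@@H]1O`: not yet measured

In a functional assay on B16 cells (Mus musculus) for antiproliferative activity, with a stated time of 72 h (on this read-out lower numbers stand for stronger inhibition and higher numbers for weaker inhibition), compound 3 gives > 166000 nM, which is a limit and not a number. It shares this position with the other two measured compounds: the limit of > 166000 nM in this assay, at which 3 of the 3 values shown sit.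

Compound 4 carries 3-chloro-4-fluorophenyl in place of 2,4-difluorophenyl on a saturated chain carbon bound to a nitrogen on an aromatic ring.

Going by the values given here, three measured steps bear on this change: a step that the two limits leave unreadable from compound 1 to compound 3, a step that the two limits leave unreadable from compound 2 to compound 3 and a step that the two limits leave unreadable from compound 1 to compound 2. None of them has a readable size, so they give no direction. On this evidence, no step beyond the scatter is expected in this assay, and compound 4 is likely to be reported only as a limit as well.

For compound 4 the estimated step is a step that the limit leaves unreadable from compound 3 to compound 4.

Compound 4 is expected at 170000 nM, with an estimated range of 70000 nM to 350000 nM.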

Compound 4, half-maximal inhibitory concentration: 167000 nM
The estimate for compound 4 lay 1.0-fold (0.01 log units) above the measured number, and the stated range covers the measured number.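

Going by these compounds alone, no step to compound 4 can be read from compound 1, compound 2 or compound 3, whose results in this assay are limits and not numbers: the limit of > 166000 nM in this assay, at which 3 of the 4 values shown sit. The compounds shown leave open whether changing the substituted benzyl group on the shared core shifts this read-out at all.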